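This account rests on a few compounds, and the source may have more. Where it says the series, first, only, none or still open, it means among the compounds named here.

For the measured compounds named here, compound 1 `Cc1ccc2cc(-c3ccc(Br)nn3)c(=O)oc2c1` is one of two compounds measured in an assay on cells for inhibition of Amine oxidase [flavin-containing] B (Homo sapiens), read by fluorescence and Amplex Red, with a stated time of 15 min; on this read-out higher numbers stand for weaker inhibition and lower numbers for stronger inhibition; compound 1 gives 750 nM, the lower of the two numbers, and compound 2 `COc1ccc2cc(-c3ccc(Br)nn3)c(=O)oc2c1` gives 3050 nM. Going by the values given here, the only step measured so far, a 4.1-fold higher number from compound 1 to compound 2 (0.61 log units; beyond the scatter), concerns the other ring of the shared core. Compound 3 `COc1ccc(-c2cc3ccc(C)cc3oc2=O)nn1` differs from compound 1 in another way: methoxy in place of bromo on an aromatic carbon. Among the compounds with values here, no measured step touches this position, so the step from compound 1 to compound 2 is only a loose guide; it shows that exchanging a small group for methoxy on the core weakened inhibition modestly, but at a different place. The step from compound 1 to compound 3 is therefore expected to be small to modest, most likely toward a higher number, with wide uncertainty: a 2.0-fold higher number from compound 1 to compound 3 (0.30 log units; within the scatter). On that basis compound 3 is estimated at 1500 nM, within the range 400 nM to 6000 nM in this assay.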

Compound 3, half-maximal inhibitory concentration: 13500 nM
Compound 3: the middle estimate sits 9.0-fold (0.95 log units) below what was measured; measured number outside the range, above it.
By their numbers in this assay, from the lowest: compound 1; then compound 2; then compound 3.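

In this assay, the aromatic carbon next to the ring nitrogen, in the six-membered aromatic ring with 2 nitrogen, proves sensitive to its substituent: methoxy in place of bromo gives an 18-fold higher number from compound 1 to compound 3 (1.26 log units; beyond the scatter). This is the first reading at this position, and the step is larger than the one on the other ring of the shared core, a 4.1-fold higher number from compound 1 to compound 2 (0.61 log units; beyond the scatter), so among the groups shown here, bromo goes with the stronger inhibition. Nothing available explains why this exchange weakens inhibition so much.

The compounds shown leave open whether bromo is specifically favoured at this carbon or methoxy specifically disfavoured, which chloro, methyl or an amine there could help to separate. They also leave open whether the step would be the same size with methoxy rather than methyl on the other ring.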